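A few compounds are considered here, and "the series" means these few. Any claim that something is new, unique, unknown or untested is made for them only; others in the source may bear on it.

In an ADME assay on HepG2 cells (Homo sapiens) for cytotoxicity, read by MTT assay, with a stated time of 72 h (on this read-out lower numbers stand for stronger inhibition and higher numbers for weaker inhibition), compound 1 `Cc1ccc(S(=O)(=O)Cc2nc(Nc3cccc(C(F)(F)F)c3)c3ccccc3n2)cc1` gives > 25000 nM as a limit and not a number. Compound 2 `CC(C)=Cc1nc(Nc2cccc(C(F)(F)F)c2)c2cc([N+](=O)[O-])ccc2n1` gives > 100000 nM as a limit too. Compound 3 `Cc1ccc(S(=O)(=O)Cc2nc(Nc3ccccc3)c3cc([N+](=O)[O-])ccc3n2)cc1` gives > 25000 nM as a limit as well, so it has no number of its own and stands with the two other values, all limits. Compound 4 `Cc1ccc(S(=O)(=O)Cc2nc(Nc3cccc(C(F)(F)F)c3)c3cc([N+](=O)[O-])ccc3n2)cc1` differs from compound 3 by trifluoromethyl in place of hydrogen on an aromatic carbon with trifluoromethyl in place of hydrogen on an aromatic carbon, meta to a large group. Among the compounds with values here, no measured step is available to size this change. The expectation rests on compound 3 at > 25000 nM as a limit, so no shift beyond the usual scatter is expected in this assay in either direction. The expected size of a step that the limit leaves unreadable from compound 3 to compound 4 stays within that scatter. For compound 4 the estimated value is 30000 nM with an expected range from 12000 nM to 100000 nM and a good chance that the expected outcome is only a limit.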

Compound 4, half-maximal inhibitory concentration: > 100000 nM
Compound 4: a limit, no number; the forecaster's own chance of this, stated with the estimate: 80%; at least 3.3-fold (0.52 log units) between middle value and limit.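

In this assay the steps to compound 4 from compound 1, compound 2 and compound 3 cannot be read, as each pair holds only limits. The compounds shown leave open how large any of these single changes is.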